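The source may hold more compounds than are shown below. What is called first, only, known or untested is meant among the compounds shown, and "the series" means these compounds.

Of the compounds shown here, three built on one shared core have been tested in an assay on HEK293 cells for agonist activity at Toll-like receptor 8 (Homo sapiens), read by spectrophotometry; a lower number here means that less compound is needed, a higher number that more compound is needed for the effect. Compound 1 `CCCCNc1nc(N)nc(C)c1CCCCO` gives 1310 nM. Compound 2 `CCCCNc1nc(N)nc(C)c1CCCN1CCCCC1` gives 133 nM. Compound 3 `CCCCNc1nc(N)nc(C)c1CCCC` gives 780 nM. Among these, compound 3 stands apart from compound 2, as a 5.9-fold higher number from compound 2 to compound 3 (0.77 log units; beyond the scatter) lies beyond the scatter, but not from compound 1, since a 1.7-fold lower number from compound 1 to compound 3 (0.23 log units; within the scatter) is within it.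

Compound 4 `CCCCNc1nc(N)nc(C)c1CCC(C)(C)O` has not yet been measured. Its change from compound 3 is 1-hydroxy-1-methylethyl in place of ethyl on a saturated chain carbon, two bonds along the chain from an aromatic carbon. The step that bears most directly on this is a 1.7-fold lower number from compound 1 to compound 3 (0.23 log units; within the scatter), where a hydroxy group on a saturated chain carbon, four bonds along the chain from an aromatic carbon, made no difference beyond the scatter. For the measured compounds named here, the one large step seen so far, a 9.8-fold lower number from compound 1 to compound 2 (0.99 log units; beyond the scatter), involves a piperidin-1-yl, which compound 4 does not carry. The 1-hydroxy-1-methylethyl group is therefore expected to shift the number in this assay little, if at all beyond the scatter. The estimate for compound 4 is 1000 nM, with a range from 300 nM to 3500 nM. This amounts to an expected step of a 1.3-fold higher number from compound 3 to compound 4 (0.11 log units; within the scatter).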

Compound 4, half-maximal effective concentration: 3140 nM
For compound 4 the middle estimate is 3.1-fold (0.50 log units) below the measured one; the range from low to high includes it.
By their numbers in this assay, from the lowest: compound 2; then compounds 3 and 1 (each within the scatter of the next); then compound 4.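

In this assay this hydroxy-bearing group clearly costs activity at this position, with a 4.0-fold higher number from compound 3 to compound 4 (0.60 log units; beyond the scatter) beyond the scatter, whereas the hydroxy group of compound 1 gave only a 1.7-fold lower number from compound 1 to compound 3 (0.23 log units; within the scatter) and stayed within it. Two hydroxy-bearing chains also separate from each other, as a 2.4-fold higher number from compound 1 to compound 4 (0.38 log units; beyond the scatter) shows, so the outcome depends on how the chain carries the hydroxy group and not merely on its presence. The piperidin-1-yl chain of compound 2 now stands much further ahead, with a 24-fold higher number from compound 2 to compound 4 (1.37 log units; beyond the scatter) as the widest gap in this set.

No measurement at hand gives a reason for the rise with compound 4. From the compounds shown here alone, whether a methoxy group or a primary amine on this chain would follow the hydroxy groups or the piperidin-1-yl stays open.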